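The compounds below may be only part of what the source reports. "The series", "measured", "known", "first", "only" and "open" are said of these compounds alone.

Within the data shown here, compound 1 `COc1ccc(NC(=O)C2c3ccccc3CCN2C(=O)c2ccc(Cl)cc2)cc1` is the only compound here with a numerical result: in a functional assay on NUGC-3 cells (Homo sapiens) for inhibition, read by sulforhodamine B assay, with a stated time of 48 h (a higher number here means a weaker inhibitor of growth, a lower number a stronger inhibitor of growth), compound 1 gives 3630 nM. Compound 2 `COc1ccccc1NC(=O)C1NCCc2ccccc21` differs from it in more than one place. In this assay compound 2 reaches only a limit, not a number, recorded as > 10000 nM, in line with the limit of > 10000 nM in this assay, at which 1 of the 2 values shown sits. Compound 3 `O=C(Nc1ccccc1O)C1c2ccccc2CCN1C(=O)c1ccc(Cl)cc1` carries 2-hydroxyphenyl in place of 4-methoxyphenyl on an amide-type nitrogen. Among the measured compounds shown here, no measured pair shows this change, so the step from compound 1 to compound 3 is expected to stay within the usual scatter, estimated as a 1.2-fold higher number from compound 1 to compound 3 (0.09 log units; within the scatter). Compound 3 is therefore expected to give 4500 nM, between 1500 nM and 12000 nM.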

Compound 3, concentration for 50% growth inhibition: > 10000 nM
Compound 3: a limit, no number; the forecaster's own chance of this, stated with the estimate: 35%; at least 2.2-fold (0.34 log units) between middle value and limit.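

Placing 2-hydroxyphenyl instead of 4-methoxyphenyl on the amide-type nitrogen gives the first readable step at this position: in this assay, the change gives an at least 2.7-fold higher number from compound 1 to compound 3 (0.44 log units; beyond the scatter). So this position does not accept every substituted phenyl group equally. Compound 3 reaches only a limit, > 10000 nM, so the full size of the step cannot be read: the limit of > 10000 nM in this assay, at which 2 of the 3 values shown sit.

As far as these compounds go, whether the loss follows the hydroxyl group or its place on the ring remains open, and a 4-hydroxyphenyl group on the same nitrogen would separate the two. From the compounds shown here alone, how a 4-aminophenyl group would fare there also remains unknown.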